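Fluorophenyl analogue of compound 1 in the antiproliferative series

The source may report more compounds than this note shows. Statements on the series, on what has been measured and on what is new or still open speak of the compounds shown alone.

Compound 1 `CCCc1ccc(-c2cc(=O)c3c(o2)C(CC)(CC)C(=O)C(CC)=C3O)cc1` is, in a functional assay on KB cells (Homo sapiens) for antiproliferative activity, read by sulforhodamine B assay, with a stated time of 3 days (a higher number here means that more compound is needed for the effect, a lower number that less compound is needed), reported only as a limit of > 53 uM. Its two measured neighbours bracket the aryl substituent: compound 2 `CCC1=C(O)c2c(oc(-c3ccc(C(C)C)cc3)cc2=O)C(CC)(CC)C1=O` gives 8.13 uM in this assay, whereas compound 3 `CCOc1ccc(-c2cc(=O)c3c(o2)C(CC)(CC)C(=O)C(CC)=C3O)cc1` again reaches only a limit of > 52.4 uM in this assay. Thus an at least 6.5-fold lower number from compound 1 to compound 2 (0.81 log units; beyond the scatter), an at least 6.4-fold higher number from compound 2 to compound 3 (0.80 log units; beyond the scatter), and a step that the two limits leave unreadable from compound 1 to compound 3.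

Compound 4 `CCC1=C(O)c2c(oc(-c3ccccc3F)cc2=O)C(CC)(CC)C1=O` changes a different part of the aryl group: 2-fluorophenyl in place of 4-propylphenyl on an aromatic carbon. Within the data shown here, none of the measured steps bears on a 2-fluorophenyl; all three concern the group at the para position of the phenyl ring, and only the isopropyl of compound 2 moved the number below the limit at the limit of > 53 uM in this assay, at which 1 of the 3 values shown sits. Among the measured compounds shown here, with no direct precedent, the expectation for compound 4 is a modest gain at most, with a real chance of another limit; the estimated step is an at least 1.7-fold lower number from compound 1 to compound 4 (0.24 log units; that floor lies within the scatter). The expected value for compound 4 in this assay is 30 uM, between 8 uM and 60 uM.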

Compound 4, concentration for half-maximal effect: > 56.2 uM
Compound 4 gave a limit, no number (the forecaster's own chance of this, stated with the estimate: 40%); at least 1.8-fold (0.27 log units) between middle value and limit.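

Compound 4 in this assay gives > 56.2 uM, which is a limit and not a number, so a fluorine-bearing aryl group at this place, next to the ring oxygen, does not give a readable value either. The step from the one readable compound is an at least 6.9-fold higher number from compound 2 to compound 4 (0.83 log units; beyond the scatter), and among the four aryl groups shown, 4-isopropylphenyl alone gives a number. The steps among compound 1, compound 3 and compound 4 cannot be read, as each joins two limits.

From the compounds shown here alone, it remains open whether the limit of compound 4 goes with the fluorine or with the missing 4-substituent, a question that a plain phenyl group would address. Going by these compounds, it is also open whether the value of compound 2 is particular to isopropyl or extends to a tert-butyl or cyclopropyl group on the phenyl ring.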